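Compound 3 to compound 4: replacing the isopropyl group

The compounds below may be only part of what the source reports. "The series", "measured", "known", "first", "only" and "open" are said of these compounds alone.

In a functional assay on KB 3-1 cells (Homo sapiens) for cytotoxicity, read by MTT assay, with a stated time of 72 h (on this read-out lower numbers stand for stronger inhibition and higher numbers for weaker inhibition), three compounds sharing one core have been measured so far: compound 1 (`O=C1Nc2ccccc2/C1=N/NC(=S)Nc1ccccc1`) gives 3530 nM, compound 2 (`O=C1Nc2ccccc2/C1=N/NC(=S)NC1CCCCC1`) gives 9140 nM and compound 3 (`CC(C)NC(=S)N/N=C1\C(=O)Nc2ccccc21`) gives 39300 nM. Compound 3 therefore has the highest number of the three, and its gaps to the other two lie beyond the scatter.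

The next structure is compound 4 (`O=C1Nc2ccccc2/C1=N/NC(=S)Nc1ccc(F)cc1`), with 4-fluorophenyl in place of isopropyl on an amide-type nitrogen.

The most relevant measurement is an 11-fold higher number from compound 1 to compound 3 (1.05 log units; beyond the scatter), which is large and, read in reverse, links isopropyl to phenyl. The modest steps of a 2.6-fold higher number from compound 1 to compound 2 (0.41 log units; beyond the scatter) and a 4.3-fold higher number from compound 2 to compound 3 (0.63 log units; beyond the scatter) place cyclohexyl in the middle of these three compounds, and none of the three goes against that order. Among the measured groups, the phenyl of compound 1 at 3530 nM is the closest match to 4-fluorophenyl. For the measured compounds named here, no measured compound carries fluorine, so its contribution remains unknown and the range is kept wide.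

The expected change is large and toward a lower number: a 12-fold lower number from compound 3 to compound 4 (1.09 log units; beyond the scatter). For compound 4 the estimated value in this assay is 3200 nM, with an expected range of 1200 nM to 9000 nM.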

Compound 4, half-maximal inhibitory concentration: 14200 nM
Beside the measured number, compound 4's estimate is 4.4-fold (0.65 log units) below it; measured number outside the range, above it.
By their numbers in this assay, from the lowest: compound 1; then compounds 2 and 4 (each within the scatter of the next); then compound 3.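

In this assay, a phenyl ring on the amide-type nitrogen does not by itself secure the low number of compound 1: fluoro in place of hydrogen on an aromatic carbon gives a 4.0-fold higher number from compound 1 to compound 4 (0.60 log units; beyond the scatter), so this aromatic ring is sensitive to a change of a single atom. Set against the alkyl end of the series, 4-fluorophenyl in place of isopropyl still gives a 2.8-fold lower number from compound 3 to compound 4 (0.44 log units; beyond the scatter), while 4-fluorophenyl in place of cyclohexyl gives a 1.6-fold higher number from compound 2 to compound 4 (0.19 log units; within the scatter), so these two groups cannot be told apart here and an aromatic ring at this place is no longer enough to separate a compound from the cyclohexyl one. No measurement on hand accounts for the effect of the fluoro group.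

The compounds shown leave open whether this rise belongs to fluoro itself or would also appear with chloro, methyl or methoxy on the same phenyl ring. Also open, from the compounds shown here alone, is how a benzyl group, a cyclopentyl ring or a longer chain such as n-butyl would rank on this nitrogen against phenyl, cyclohexyl and isopropyl.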